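A few compounds are considered here, and "the series" means these few. Any claim that something is new, unique, unknown or untested is made for them only; others in the source may bear on it.

Measured in a functional assay on HepG2 cells (Homo sapiens) for inhibition, read by MTT assay, with a stated time of 3 days; a lower number here means a stronger inhibitor, a higher number a weaker inhibitor:
- compound 1 `COc1cc(-c2nc3ccccc3s2)ccc1OCC(=O)NNC(=O)CCl`: 2890 nM
- compound 2 `COc1cc(-c2nc3ccccc3s2)ccc1OCC(=O)NNC(O)CN(C)CC(=O)O`: 3030 nM
- compound 3 `COc1cc(-c2nc3ccccc3s2)ccc1OCC(=O)NNC(=O)CN1CCC[C@H]1C(=O)O`: 2650 nM

Compound 3 stands level with compound 1 and compound 2, as all three values lie within the scatter of each other. Compound 4 `CCOC(=O)[C@H](CS)N(CC(=O)NNC(=O)COc1ccc(-c2nc3ccccc3s2)cc1OC)C(C)=O` changes one group of compound 3: acetyl(1-(ethoxycarbonyl)-2-sulfanylethyl)amino in place of 2-carboxypyrrolidin-1-yl on a saturated chain carbon bound to a carbonyl carbon. Within the data shown here, the entering group has no ring, and no measured compound carries it. The closest evidence is the swap of chloro for 2-carboxypyrrolidin-1-yl at that same place, which gave a 1.1-fold lower number from compound 1 to compound 3 (0.04 log units; within the scatter). The other measured steps were equally small: a 1.0-fold higher number from compound 1 to compound 2 (0.02 log units; within the scatter) and a 1.1-fold lower number from compound 2 to compound 3 (0.06 log units; within the scatter). No shift beyond the scatter is therefore expected in this assay, and the expected step is a 1.1-fold higher number from compound 3 to compound 4 (0.02 log units; within the scatter). For compound 4 the estimated value is 2800 nM, with an expected range from 1200 nM to 6500 nM.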

Compound 4, half-maximal inhibitory concentration: 3010 nM
The estimate for compound 4 lay 1.1-fold (0.03 log units) below the measured number; measured number inside the range.
By their numbers in this assay, from the lowest: compounds 3, 1, 4 and 2 (each within the scatter of the next).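

In this assay, the place on a saturated chain carbon bound to a carbonyl carbon also accepts a group with no ring: acetyl(1-(ethoxycarbonyl)-2-sulfanylethyl)amino in place of 2-carboxypyrrolidin-1-yl gives a 1.1-fold higher number from compound 3 to compound 4 (0.06 log units; within the scatter), even with 12 heavy atoms entering. Set against chloro, the same group gives a 1.0-fold higher number from compound 1 to compound 4 (0.02 log units; within the scatter), so a single chloro atom, the ring and this open chain all read alike here. Nothing measured here bears on the reason for this sameness. Going by these compounds, whether a phenyl ring or a simple primary amine at this place would move the number stays open.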